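Ethynyl series: dimethylfuranyl in place of methoxyphenyl

The compounds below may be only part of what the source reports. "The series", "measured", "known", "first", "only" and "open" are said of these compounds alone.

Measured so far:
compound 1, `CNC(=O)[C@@]12C[C@@H]1[C@@H](n1cnc3c(NC)nc(C#Cc4ccc(-c5ccccc5)cc4)nc31)[C@H](O)[C@@H]2O`, 18%
compound 2, `CNC(=O)[C@@]12C[C@@H]1[C@@H](n1cnc3c(NC)nc(C#Cc4ccc(OC)cc4)nc31)[C@H](O)[C@@H]2O`, 10%

Both values come from an assay on CHO cells for displacement of a labelled ligand from adenosine receptor A1 (Homo sapiens), read by scintillation counting, with a stated time of 60 min, tested at 10 uM; a higher number here means more inhibition at the concentration tested (going by the name of the read-out), a lower number less inhibition. Compound 2 gives 10% and stands at the lower of the two numbers, with compound 1 as the nearest neighbour; the step of a number 8 percentage points lower from compound 1 to compound 2 (within the scatter) is within the scatter, so the two values cannot be ordered.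

Compound 3, `CNC(=O)[C@@]12C[C@@H]1[C@@H](n1cnc3c(NC)nc(C#Cc4cc(C)c(C)o4)nc31)[C@H](O)[C@@H]2O`, is not yet measured. The change from compound 2 is 4,5-dimethylfuran-2-yl in place of 4-methoxyphenyl on a triple-bonded carbon. Within the data shown here, no measured step bears on this change: the only step available, a number 8 percentage points lower from compound 1 to compound 2 (within the scatter), concerns a different exchange on the six-membered aromatic ring and is itself within the scatter. Both measured compounds sit at low inhibition, and without a relevant step the expectation for compound 3 is a number of the same size, with a step of a number 2 percentage points higher from compound 2 to compound 3 (within the scatter) that is not expected to exceed the scatter. The estimate for compound 3 is therefore 12%, with a range from 0% to 30%.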

Compound 3, a percentage reported as inhibition, at one concentration (the size of the read-out at that concentration, not a potency): 15%
Beside the measured number, compound 3's estimate is 3 percentage points below it; the measured number falls inside the stated range.
By their numbers in this assay, from the lowest: compounds 2, 3 and 1 (each within the scatter of the next).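

On the triple-bonded carbon, the series now includes a five-membered aromatic ring with 1 hetero atom as well as six-membered aromatic rings of carbon only. In this assay, 4,5-dimethylfuran-2-yl in place of 4-methoxyphenyl gives a number 5 percentage points higher from compound 2 to compound 3 (within the scatter), and in place of 4-phenylphenyl it gives a number 3 percentage points lower from compound 1 to compound 3 (within the scatter), so neither exchange separates the compounds in this read-out. No supporting measurement accounts for this result.

All three groups shown on this carbon are aromatic rings, so it remains open whether any substituent here can move the number beyond the scatter. A simple aminomethyl group or a carboxylic acid on the same triple-bonded carbon would test that question on the shared core.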